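From Pyridinylmethyl to Allyl on the Aromatic Nitrogen

The compounds below may be only part of what the source reports. "The series", "measured", "known", "first", "only" and "open" are said of these compounds alone.

Three compounds sharing one core differ only in the group carried on an aromatic nitrogen. Compound 1 `COc1ccc(-c2cc(=O)n(Cc3cccnc3)nc2-c2ccc(OC)cc2)cc1` gives 430 nM in a functional assay on HL-60 cells (Homo sapiens) for inhibition (on this read-out higher numbers stand for weaker inhibition and lower numbers for stronger inhibition), the lowest of the three numbers. Compound 3 `COc1ccc(-c2cc(=O)n(C3CCCC3)nc2-c2ccc(OC)cc2)cc1` gives 510 nM in this assay, and the step of a 1.2-fold higher number from compound 1 to compound 3 (0.07 log units; within the scatter) stays within the scatter. Compound 2 `COc1ccc(-c2cc(=O)n(C(C)C)nc2-c2ccc(OC)cc2)cc1` gives 1320 nM in this assay; the step of a 3.1-fold higher number from compound 1 to compound 2 (0.49 log units; beyond the scatter) is the widest gap from compound 1, and a 2.6-fold lower number from compound 2 to compound 3 (0.41 log units; beyond the scatter) shows that cyclopentyl regains most of what isopropyl lost.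

Compound 4 `C=CCn1nc(-c2ccc(OC)cc2)c(-c2ccc(OC)cc2)cc1=O` has not yet been measured in this assay. Its difference from compound 1 is vinyl in place of pyridin-3-yl on a saturated chain carbon bound to an aromatic nitrogen. Both measured steps from compound 1 replace the (pyridin-3-yl)methyl group: the move to isopropyl in a 3.1-fold higher number from compound 1 to compound 2 (0.49 log units; beyond the scatter) weakened inhibition modestly, whereas the move to cyclopentyl in a 1.2-fold higher number from compound 1 to compound 3 (0.07 log units; within the scatter) did not. Allyl is a short chain with no ring, so a modest rise in the number, of roughly the size seen toward isopropyl or somewhat less, is expected, though a step within the scatter cannot be excluded. The expected step is a 1.9-fold higher number from compound 1 to compound 4 (0.27 log units; within the scatter). Compound 4 is therefore expected to give about 800 nM in this assay, within a range from 350 nM to 2000 nM.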

Compound 4, half-maximal inhibitory concentration: > 100000 nM
Compound 4 was reported as a limit; the forecaster's own chance of this, stated with the estimate: 3%; at least 120-fold (2.09 log units) between middle value and limit.
By their numbers in this assay, from the lowest: compounds 1 and 3 (each within the scatter of the next); then compound 2. At a limit, above all of these: compound 4.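

Among the earlier compounds the widest step at this position was modest, yet allyl stands far from all three, with large steps against (pyridin-3-yl)methyl (an at least 230-fold higher number from compound 1 to compound 4 (2.36 log units; beyond the scatter)), against cyclopentyl (an at least 190-fold higher number from compound 3 to compound 4 (2.29 log units; beyond the scatter)) and against isopropyl (an at least 75-fold higher number from compound 2 to compound 4 (1.87 log units; beyond the scatter)). The number for compound 4 is a limit of the assay and not a measured value: the limit of > 100000 nM in this assay, at which 1 of the 4 values shown sits. The absence of a ring does not by itself separate the groups at this position, as isopropyl also has no ring and compound 2 still gives a measured 1320 nM in this assay.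

The compounds shown leave open whether the double bond outside aromatic rings is what sets allyl apart from isopropyl, a question that a saturated propyl chain on the same nitrogen would address directly. They also leave open whether the aromatic ring of the (pyridin-3-yl)methyl group has any part in the result, which a benzyl group or a longer chain ending in an amine could begin to show.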